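Fluoro in place of methoxy, two placements compared

The source may hold more compounds than are shown below. What is called first, only, known or untested is meant among the compounds shown, and "the series" means these compounds.

Compound 1 `COc1ccc(OS(=O)(=O)c2ccc(N3CCN(C)C3=O)cc2)cc1` and compound 2 `CN1CCN(c2ccc(S(=O)(=O)Oc3ccc(F)cc3)cc2)C1=O` share one core. In a functional assay on MCF7 cells (Homo sapiens) for antiproliferative activity, read by sulforhodamine B assay, with a stated time of 48 h (on this read-out higher numbers stand for weaker inhibition and lower numbers for stronger inhibition), compound 1 gives 95000 nM. For compound 2 this assay reports only a limit, > 100000 nM. The change fluoro in place of methoxy on an aromatic carbon therefore made an at least 1.0-fold higher number from compound 1 to compound 2 (0.02 log units; that floor lies within the scatter), and the size of that step is bounded by the limit of > 100000 nM in this assay, at which 1 of the 3 values shown sits. Compound 3 `CCN1CCN(c2ccc(S(=O)(=O)Oc3cccc(OC)c3)cc2)C1=O` gives 14000 nM in this assay; the difference between its core and that of compound 1 is not broken down here. Compound 4 `CCN1CCN(c2ccc(S(=O)(=O)Oc3cccc(F)c3)cc2)C1=O` has not yet been measured. It differs from compound 3 by fluoro in place of methoxy on an aromatic carbon, the same kind of change as before, though here the place is meta to a large group rather than para to a large group. Resting on the step of an at least 1.0-fold higher number from compound 1 to compound 2 (0.02 log units; that floor lies within the scatter), compound 4 is expected to show a 2.0-fold higher number from compound 3 to compound 4 (0.30 log units; within the scatter) in this assay. Compound 4 is estimated at 28000 nM, between 10000 nM and 90000 nM.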

Compound 4, half-maximal inhibitory concentration: > 100000 nM
Compound 4: a limit, no number; the forecaster's own chance of this, stated with the estimate: 12%; at least 3.5-fold (0.55 log units) between middle value and limit.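

In this assay compound 4 gives > 100000 nM, which is a limit and not a number. On the core of compound 3, going from 3-methoxyphenyl to 3-fluorophenyl gives a clear step, an at least 7.1-fold higher number from compound 3 to compound 4 (0.85 log units; beyond the scatter), but whether the change carries over at the same size from the core of compound 1 cannot be said: the same change on two cores in this assay, an at least 1.0-fold higher number (0.02 log units; that floor lies within the scatter) from compound 1 to compound 2 and an at least 7.1-fold higher number (0.85 log units; beyond the scatter) from compound 3 to compound 4; the limit leaves it open whether they differ. Neither step has a known size, only a floor, so the two cores show at most a shared direction: the limit of > 100000 nM in this assay, at which 2 of the 4 values shown sit.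

Open, from the compounds shown here alone, is whether a group other than methoxy or fluoro on that aromatic ring, such as an amine, a chloro or a hydroxyl, gives a measurable value. Also open, going by these compounds, is how much of the gap between compound 1 and compound 3 comes from the core and how much from the place of the methoxy.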